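Moving one methoxy group on the aryl ring

The compounds below may be only part of what the source reports. "The series", "measured", "known", "first", "only" and "open" are said of these compounds alone.

Compound 1 `COc1cc(C(=O)c2sc3ccccc3c2-c2ccc(Cl)cc2)cc(OC)c1OC`: 3300 nM
Compound 2 `COc1ccc(-c2c(C(=O)c3cc(OC)c(OC)c(OC)c3)sc3ccccc23)c(OC)c1`: 4600 nM

Within the data shown here, in a functional assay on HL-60 cells (Homo sapiens) for antiproliferative activity, read by MTT assay, with a stated time of 72 h (a lower number here means a stronger inhibitor, a higher number a weaker inhibitor), compound 2 stands within the scatter of compound 1, the only other compound measured. Compound 3 `COc1ccc(OC)c(-c2c(C(=O)c3cc(OC)c(OC)c(OC)c3)sc3ccccc23)c1` has the same atoms as compound 2, joined differently, with 2,5-dimethoxyphenyl in place of 2,4-dimethoxyphenyl on an aromatic carbon. Among the measured compounds shown here, one measured step bears on this change. It altered the group on the same aromatic carbon, and a 1.4-fold higher number from compound 1 to compound 2 (0.14 log units; within the scatter). No step beyond the scatter is therefore expected in this assay, and no direction is favoured. The expected change is a 1.2-fold lower number from compound 2 to compound 3 (0.06 log units; within the scatter). Compound 3 is estimated at 4000 nM, with an expected range of 1500 nM to 10000 nM.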

Compound 3, half-maximal inhibitory concentration: > 10000 nM
Compound 3 ended at the assay's limit (the forecaster's own chance of this, stated with the estimate: 10%); middle value at least 2.5-fold (0.39 log units) away from the limit.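

In this assay compound 3 ended at the limit of the assay, and its value is a limit, not a number: the limit of > 10000 nM in this assay, at which 1 of the 3 values shown sits. Moving a methoxy group, from 2,4-dimethoxyphenyl to 2,5-dimethoxyphenyl, gave an at least 2.1-fold higher number from compound 2 to compound 3 (0.33 log units; beyond the scatter), so this arrangement matters at this position in a way the earlier within-scatter step did not reveal. Replacing 4-chlorophenyl with 2,5-dimethoxyphenyl gave an at least 3.0-fold higher number from compound 1 to compound 3 (0.48 log units; beyond the scatter).

On these data alone, how far past the limit compound 3 lies remains open, and so does the full size of both steps. As far as these compounds go, it is also open how an amine or a hydroxyl group on this aryl ring would behave.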